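Trimming a Methyl from the Piperazine Ring

The source may hold more compounds than are shown below. What is called first, only, known or untested is meant among the compounds shown, and "the series" means these compounds.

Measured so far in a physicochemical assay for lipophilicity; on this read-out lower numbers stand for lower lipophilicity and higher numbers for higher lipophilicity:
compound 1 `Cc1nc(-c2cc(C(F)(F)F)ccc2[C@H]2CCOc3cc(S(=O)(=O)Nc4ccncn4)ccc32)co1` gives "not determined" (no result reported)
compound 2 `Cc1nc(-c2cc(C(F)(F)F)ccc2[C@H]2CCOc3cc(S(=O)(=O)Nc4cccc(F)n4)ccc32)co1` gives 4
compound 3 `CN1CCN(c2cc(C(F)(F)F)ccc2[C@H]2CCOc3cc(S(=O)(=O)Nc4nccs4)ccc32)CC1` gives 2.1

Of the two numbers available, compound 3 (2.1) holds the lower one, and its gap to compound 2 lies beyond the usual scatter of repeat measurements. Compound 1 offers no number to compare. Compounds 2 and 3 differ in more than one place, so that gap cannot be pinned on any single group.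

Compound 4 `O=S(=O)(Nc1nccs1)c1ccc2c(c1)OCC[C@@H]2c1ccc(C(F)(F)F)cc1N1CCNCC1` has not yet been measured. It differs from compound 3 in one place (hydrogen in place of methyl on an amine nitrogen in a ring): hydrogen in place of methyl on an amine nitrogen in a ring, turning 4-methylpiperazin-1-yl into piperazin-1-yl.

For the measured compounds named here, no measured pair shows this change on its own, so the expectation starts from compound 3 (2.1) and remains uncertain. A modest fall is expected (a number 0.40 log units lower from compound 3 to compound 4 (beyond the scatter)), about the size of the scatter or slightly larger. For compound 4 the estimated value is 1.7, with an expected range from 1.2 to 2.2 in this measurement.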

Compound 4, distribution coefficient: 1.4
Compound 4: the middle estimate sits 0.30 log units above what was measured; low and high end bracket the measured number.
By their numbers in this assay, from the lowest: compound 4; then compound 3; then compound 2.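

For the compounds shown here, compound 3 and compound 4 are the first pair here that differ in one place only, so this gap, unlike the earlier one, can be tied to a single change. Putting hydrogen in place of methyl on the amine nitrogen of the piperazine ring, which removes one carbon, gives a number 0.70 log units lower from compound 3 to compound 4 (beyond the scatter) in this assay and shows that this small edit at this position is enough to move the read-out past the scatter. Nothing measured here explains why the number moves.

As far as these compounds go, this single pair is all that speaks for the position, so it remains open how the read-out would respond to an ethyl or an acetyl group on the same nitrogen. From the compounds shown here alone, it is also open whether the same change would give a step of similar size in a compound that differs from compound 3 elsewhere.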